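This account rests on a few compounds, and the source may have more. Where it says the series, first, only, none or still open, it means among the compounds named here.

Compound 3, `CCN(Cc1cccnc1)c1cccc(C(=O)N2CCc3ccc(OS(N)(=O)=O)cc3C2)c1`, gives 14.3% in an assay on HEK293 cells for inhibition of Steryl-sulfatase (Homo sapiens), tested at 0.1 uM (on this read-out lower numbers stand for a weaker effect and higher numbers for a stronger effect at the one concentration tested), the lowest of the three numbers shown, although its nearest neighbour compound 2, `CCCN(Cc1ccccc1)c1cccc(C(=O)N2CCc3ccc(OS(N)(=O)=O)cc3C2)c1`, gives 23.1% and the step of a number 8.8 percentage points lower from compound 2 to compound 3 (within the scatter) stays within the scatter. Compound 1, `CC(C)CCN(CCC(C)C)c1cccc(C(=O)N2CCc3ccc(OS(N)(=O)=O)cc3C2)c1`, gives 32.3%, and the step of a number 18 percentage points lower from compound 1 to compound 3 (beyond the scatter) lies beyond the scatter. Compound 4, `CCCN(CCC)c1cccc(C(=O)N2CCc3ccc(OS(N)(=O)=O)cc3C2)c1`, differs from compound 3 by dipropylamino in place of ethyl((pyridin-3-yl)methyl)amino on an aromatic carbon. Like the diisopentylamino of compound 1, the entering dipropylamino has no ring, so the steps that bear on this change are a number 18 percentage points lower from compound 1 to compound 3 (beyond the scatter) and the smaller a number 9.2 percentage points lower from compound 1 to compound 2 (within the scatter). A partial return toward the number of compound 1 is therefore expected, and for compound 4 a modest rise of a number 10.7 percentage points higher from compound 3 to compound 4 (beyond the scatter) is estimated, giving 25% with a range from 12% to 38%.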

Compound 4, a percentage reported as inhibition, at one concentration (the size of the read-out at that concentration, not a potency): 8.3%
The estimate for compound 4 lay 16.7 percentage points above the measured number; measured number below the stated range.
By their numbers in this assay, from the lowest: compounds 4, 3, 2 and 1 (each within the scatter of the next, the first and the last beyond it).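

Taking away the ring did not bring the number back toward compound 1: the step of a number 6 percentage points lower from compound 3 to compound 4 (within the scatter) means dipropylamino and ethyl((pyridin-3-yl)methyl)amino cannot be told apart here. Having no ring is therefore not what sets compound 1 apart, as the step of a number 24 percentage points lower from compound 1 to compound 4 (beyond the scatter) separates two ring-free amines. Ethyl in place of phenyl on the chain also counts, with a number 14.8 percentage points lower from compound 2 to compound 4 (beyond the scatter) as its step. Still open, as far as these compounds go, is how dibutylamino, with chains between these lengths, or piperidine, with the nitrogen closed into a ring, would behave. No evidence is available to explain these differences.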